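Cyclising the amino acid side chain of the amide

This account rests on a few compounds, and the source may have more. Where it says the series, first, only, none or still open, it means among the compounds named here.

Three amides sharing one core have been measured in an assay on isolated protein for inhibition of Rho-associated protein kinase 2 (Homo sapiens); a higher number here means a weaker inhibitor, a lower number a stronger inhibitor. Compound 1 `CC(C)C[C@@H](N)C(=O)Nc1cc2cc[nH]c(=O)c2cc1Cl` gives 19 nM, compound 2 `CC(C)C[C@H](N)C(=O)Nc1cc2cc[nH]c(=O)c2cc1Cl` gives 340 nM and compound 3 `CC(C)(C)C[C@@H](N)C(=O)Nc1cc2cc[nH]c(=O)c2cc1Cl` gives 110 nM. Compound 3 thus stands second highest of the three numbers, closer to compound 2 than to compound 1. The step of an 18-fold higher number from compound 1 to compound 2 (1.25 log units; beyond the scatter) is large, and because the fact that compounds 1 and 2 differ only in the configuration as drawn the configuration at the chain carbon alone decides it. The step of a 5.8-fold higher number from compound 1 to compound 3 (0.76 log units; beyond the scatter) is modest, as is a 3.1-fold lower number from compound 2 to compound 3 (0.49 log units; beyond the scatter).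

Compound 4 `O=C(Nc1cc2cc[nH]c(=O)c2cc1Cl)[C@@H]1CCCN1` has not yet been measured. It differs from compound 3 by pyrrolidin-2-yl in place of 1-amino-3,3-dimethylbutyl on a carbonyl carbon. Among the measured compounds shown here, no measured step removes the branched side chain or closes the amine into a ring, so the steps between compound 1 and compound 3 bear on it only loosely: both show that changing the chain at this carbon moves the number by a modest amount, while the step between compound 1 and compound 2 shows that configuration at this carbon can move it strongly. Taken together, a modest shift in either direction seems the likely outcome, with a wide range. Compound 4 is therefore expected to give about 150 nM, between 30 nM and 800 nM, which means an estimated step of a 1.4-fold higher number from compound 3 to compound 4 (0.13 log units; within the scatter).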

Compound 4, half-maximal inhibitory concentration: 35 nM
Compound 4: the middle estimate sits 4.3-fold (0.63 log units) above what was measured; the range from low to high includes it.
By their numbers in this assay, from the lowest: compounds 1 and 4 (each within the scatter of the next); then compound 3; then compound 2.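

Closing the amine into a ring does not cost activity at this position: in this assay, the step of a 1.8-fold higher number from compound 1 to compound 4 (0.27 log units; within the scatter) lies within the scatter, so pyrrolidin-2-yl and 1-amino-3-methylbutyl cannot be told apart here. The earlier compounds shown here showed only losses from compound 1, whereas the ring gives a clear gain over the other two amides, with a 3.1-fold lower number from compound 3 to compound 4 (0.50 log units; beyond the scatter) and a 9.7-fold lower number from compound 2 to compound 4 (0.99 log units; beyond the scatter), so a change on this carbonyl carbon can replace the whole open chain and keep the number low. Nothing given here explains how the ring retains this level of inhibition, and the one available observation, which concerns compounds 1 and 2 alone, does not bear on compound 4.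

The compounds shown leave open whether the mirror image of compound 4 would suffer a loss like an 18-fold higher number from compound 1 to compound 2 (1.25 log units; beyond the scatter), as the open chain does. They also leave open how ring size and substitution on the ring nitrogen matter, as in a piperidin-2-yl or azetidin-2-yl group, or an N-methylpyrrolidin-2-yl group, on the same carbonyl carbon.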